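From tert-butyl carbonyl to vinylcarbonyl on the side chain

The source may hold more compounds than are shown below. What is called first, only, known or untested is meant among the compounds shown, and "the series" means these compounds.

Compound 1 (`CCC(=O)N(CCN(C)C)Cc1ccc(C(=O)Nc2ccc(C)c(Nc3nccc(-c4cccnc4)n3)c2)cc1`) gives > 10000 nM in an ADME assay on BaF3 cells (Mus musculus) for cytotoxicity, read by CellTiter-Glo and CCK-8 assay, with a stated time of 72 h (on this read-out higher numbers stand for weaker inhibition of growth and lower numbers for stronger inhibition of growth), which is a limit of the assay and not a number. Compound 2 (`Cc1ccc(NC(=O)c2ccc(CN(CCN(C)C)C(=O)C(C)(C)C)cc2)cc1Nc1nccc(-c2cccnc2)n1`) gives > 10000 nM in this assay, again a limit and not a number. The measured series therefore stands at the limit of > 10000 nM in this assay, at which 2 of the 2 values shown sit. Tert-butyl in place of ethyl on a carbonyl carbon is the only measured change, and it gives a step that the two limits leave unreadable from compound 1 to compound 2. It therefore offers no size to carry forward.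

Compound 3 (`C=CC(=O)N(CCN(CC)CC)Cc1ccc(C(=O)Nc2ccc(C)c(Nc3nccc(-c4cccnc4)n3)c2)cc1`) has (2-(diethylamino)ethyl)(vinylcarbonyl)amino in place of (2-(dimethylamino)ethyl)((tert-butyl)carbonyl)amino on a saturated chain carbon bound to an aromatic carbon, and the counted difference is (2-(diethylamino)ethyl)(vinylcarbonyl)amino in place of (2-(dimethylamino)ethyl)((tert-butyl)carbonyl)amino on a saturated chain carbon bound to an aromatic carbon. Neither entering group occurs in a measured compound, so the direction is a tentative judgement and not a measured trend. The expected step in this assay is an at least 1.6-fold lower number from compound 2 to compound 3 (0.22 log units; that floor lies within the scatter), leaning towards stronger inhibition of growth. A reported limit remains about as likely as a number. For compound 3 the estimate is 6000 nM, with an expected range of 1500 nM to 10000 nM.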

Compound 3, concentration for 50% growth inhibition: 5450 nM
For compound 3 the middle estimate is 1.1-fold (0.04 log units) above the measured one, and the stated range covers the measured number.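

In this assay, for the compounds shown here, compound 3 is the first compound to give a number rather than a limit, at (5450 nM), so a change on a saturated chain carbon bound to an aromatic carbon can bring growth inhibition into the readable range. Replacing the group in compound 2 gives an at least 1.8-fold lower number from compound 2 to compound 3 (0.26 log units; that floor lies within the scatter) and replacing the propanoyl-bearing group in compound 1 gives an at least 1.8-fold lower number from compound 1 to compound 3 (0.26 log units; that floor lies within the scatter) and each of these is only a floor, so the direction towards stronger inhibition of growth has no measured size. The step between compound 1 and compound 2 still cannot be read, and the series remains mostly at the limit of the assay: (the limit of > 10000 nM in this assay, at which 2 of the 3 values shown sit).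

The entering group in compound 3 differs from both partners in its diethylamino end and in its vinylcarbonyl end, so these compounds leave open which of the two carries the step. Also open, going by these compounds, is how this position would read with a chloroacetyl group on the nitrogen or with a pyrrolidine in place of the diethylamino end.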